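Swapping formyl for nitro on an aromatic carbon

The source may report more compounds than this note shows. Statements on the series, on what has been measured and on what is new or still open speak of the compounds shown alone.

Values in a functional assay (Homo sapiens); on this read-out lower numbers stand for stronger inhibition and higher numbers for weaker inhibition:
- Compound 1 `C#Cc1cccc(-c2nccc3nc(N)nn23)c1`: 12600 nM; 12600 nM (2 entries)
- Compound 2 `Nc1nc2ccnc(-c3cccc(C(Cl)Cl)c3)n2n1`: 1000 nM
- Compound 3 `Nc1nc2ccnc(-c3cccc(C=O)c3)n2n1`: 700 nM

Compound 3 and compound 2 lie within the usual scatter of each other, and both numbers are well under that of compound 1. Compound 4 `Nc1nc2ccnc(-c3cccc([N+](=O)[O-])c3)n2n1`, not yet measured, carries nitro in place of formyl on an aromatic carbon, meta to a large group: nitro in place of formyl on an aromatic carbon.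

Among the measured compounds shown here, one measured step bears directly on this change, since it swaps the group on the same carbon: a 1.4-fold lower number from compound 2 to compound 3 (0.15 log units; within the scatter). From the compounds shown here alone, that single step stayed within the scatter, which is thin support, and nitro itself is untested on this core. Compound 1, which has a different group there, gives 12600 nM; 12600 nM (2 entries), so a larger move cannot be ruled out and the range stays wide.

No step beyond the scatter is expected in this assay, and the estimated change is a 1.1-fold higher number from compound 3 to compound 4 (0.06 log units; within the scatter). For compound 4 the expected value is 800 nM, with an estimated range of 250 nM to 2500 nM.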

Compound 4, half-maximal inhibitory concentration: 3800 nM
The estimate for compound 4 lay 4.8-fold (0.68 log units) below the measured number; the measured number lies above the stated range.
By their numbers in this assay, from the lowest: compounds 3 and 2 (each within the scatter of the next); then compound 4.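

In this assay the group on this aromatic carbon matters more than the earlier pair could show: nitro in place of formyl gives a 5.4-fold higher number from compound 3 to compound 4 (0.73 log units; beyond the scatter) and nitro in place of dichloromethyl gives a 3.8-fold higher number from compound 2 to compound 4 (0.58 log units; beyond the scatter) while formyl and dichloromethyl stayed within the scatter of each other. Nitro does not reach the far end of the series, since compound 4 still has a lower number than compound 1 at 12600 nM; 12600 nM (2 entries) and so sits in the middle of the values shown. No measurement at hand explains why nitro parts from the other two groups.

The compounds shown leave open how an amine, a carboxylic acid or a nitrile on this carbon would read in this assay and so whether formyl and dichloromethyl mark the low end of what this place allows. They also leave open whether nitro would raise the number as much on another carbon of the same ring.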